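A Lysine Side Chain Added to a Glycine Amide

The compounds below may be only part of what the source reports. "The series", "measured", "known", "first", "only" and "open" are said of these compounds alone.

Three compounds share one core and differ only at the amino-acid end. Compound 1 `NC(=O)C[C@H](NC(=O)CN(c1nc(Cl)nc2[nH]cnc12)C1CC1)C(=O)O`, compound 2 `NCCCC[C@H](NC(=O)CN(c1nc(Cl)nc2[nH]cnc12)C1CC1)C(=O)OCc1ccccc1` and compound 3 `O=C(O)CNC(=O)CN(c1nc(Cl)nc2[nH]cnc12)C1CC1` have all been tested in a functional assay on the whole organism (Tail, strain ICR) with Mus musculus as the target, in the tail flick test, with a stated time of 150 min, at a dose of 25 umol/kg by the oral route; on this read-out higher numbers stand for a stronger effect at the one dose given and lower numbers for a weaker effect. In this assay compound 1 gives 7.51%, compound 2 gives 9.88% and compound 3 gives 9.08%. Compound 3 thus stands second of the three numbers, but all three lie within the usual scatter of one another, so no order among them can be read. Going by the values given here, the one measured step that changes the same place, a number 1.6 percentage points higher from compound 1 to compound 3 (within the scatter), moved the number hardly at all.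

Compound 4 `NCCCC[C@H](NC(=O)CN(c1nc(Cl)nc2[nH]cnc12)C1CC1)C(=O)O` has not yet been tested. It differs from compound 3 by 4-aminobutyl in place of hydrogen on a saturated chain carbon bound to an amide-type nitrogen and a carbonyl carbon. Among the compounds with values here, only the step from compound 1 to compound 3 bears directly on this place, and it lay within the scatter; compound 2, whose value also sits close to that of compound 3, adds nothing that points elsewhere. The step of a number 0.4 percentage points higher from compound 3 to compound 4 (within the scatter) is therefore expected to stay within the scatter. Compound 4 is estimated at 9.5%, with a range from 3% to 17%.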

Compound 4, a percentage reported as activity, at one dose (the size of the read-out at that dose, not a potency): 11.6%
Compound 4: middle estimate off by 2.1 percentage points, on the low side; the measured number falls inside the stated range.
By their numbers in this assay, from the lowest: compounds 1, 3, 2 and 4 (each within the scatter of the next).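

In this assay, 4-aminobutyl in place of hydrogen on a saturated chain carbon bound to an amide-type nitrogen and a carbonyl carbon gives a number 2.5 percentage points higher from compound 3 to compound 4 (within the scatter) and so brings no readable change at this place. The two other comparisons read the same way: hydrogen in place of benzyl on an oxygen next to a carbonyl group gives a number 1.7 percentage points higher from compound 2 to compound 4 (within the scatter) and 3-aminopropyl in place of carbamoyl gives a number 4.1 percentage points higher from compound 1 to compound 4 (within the scatter) and neither separates the compounds. Nothing available here offers an explanation for these numbers.

Still open, going by these compounds, is whether a different group on that same chain carbon, such as a phenyl ring, a carboxylic acid or a longer chain ending in an amine, would move the number beyond the scatter. Also open, on these data alone, is how these compounds compare at other doses.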